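This account rests on a few compounds, and the source may have more. Where it says the series, first, only, none or still open, it means among the compounds named here.

The series opens with compound 1 (`COc1c([N+](=O)[O-])cc(/C=C/c2ccc3ccccc3c2)cc1[N+](=O)[O-]`). In a functional assay on P388 cells (Mus musculus) for inhibition (a lower number here means a stronger inhibitor, a higher number a weaker inhibitor), compound 1 gives > 5000 nM, which is a limit of the assay and not a number. Compound 2 (`COc1c([N+](=O)[O-])cc(/C=C\c2ccc3ccccc3c2)cc1[N+](=O)[O-]`) gives > 5000 nM, again a limit. Compound 3 (`CN(C)c1c([N+](=O)[O-])cc(/C=C/c2ccc3ccccc3c2)cc1[N+](=O)[O-]`) carries dimethylamino in place of methoxy on an aromatic carbon. As far as these compounds go, compound 3 gives > 5000 nM, also a limit, so its true position in this assay remains unknown.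

Compound 4 (`CN(C)c1c([N+](=O)[O-])cc(/C=C\c2ccc3ccccc3c2)cc1[N+](=O)[O-]`) differs from compound 3 by a single change: the two compounds have the same atoms and bonds and differ only in configuration as drawn: 1 of 1 stereo elements differ; a double bond is drawn E in compound 3 and Z in compound 4. Among the compounds with values here, the closest precedent is a step that the two limits leave unreadable from compound 1 to compound 2, where the fact that compounds 1 and 2 differ only in the configuration as drawn makes it the same kind of change. Within the data shown here, the other measured change, a step that the two limits leave unreadable from compound 1 to compound 3, shows only that the dimethylamino group leaves the read-out at its limit. Neither size can be read because of the limit of > 5000 nM in this assay, at which 3 of the 3 values shown sit, so the series offers no measured effect of the double-bond configuration and no firm direction. The expected change is therefore none beyond the scatter, and the estimated step is a step that the limit leaves unreadable from compound 3 to compound 4. Compound 4 is most likely to stay at the limit, as compound 2 did with > 5000 nM. The estimated value for compound 4 is 8000 nM, with an expected range from 2500 nM to 25000 nM.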

Compound 4, half-maximal inhibitory concentration: > 5000 nM
Compound 4 ended at the assay's limit; the forecaster's own chance of this, stated with the estimate: 75%; the middle value does not contradict the limit.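

Neither the step from compound 3 to compound 4 nor the step from compound 2 to compound 4 can be read, as compound 4 also ends at a limit of the assay: the limit of > 5000 nM in this assay, at which 4 of the 4 values shown sit. The compounds shown leave open whether double-bond configuration or dimethylamino in place of methoxy changes inhibition in this assay at all.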